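A few compounds are considered here, and "the series" means these few. Any claim that something is new, unique, unknown or untested is made for them only; others in the source may bear on it.

Three compounds have been measured in a functional assay on the whole organism (strain Holtzman) with Rattus norvegicus as the target; a higher number here means that more compound is needed for the effect, a lower number that less compound is needed:

Compound 1 `Cc1nn(C)c2c1C(c1ccccc1)=NCC(=O)N2` gives 10 mg/kg.
Compound 2 `Cc1nn(C)c2c1C(c1cccc(Cl)c1)=NCC(=O)N2` gives > 40 mg/kg, which is a limit of the assay, not a number.
Compound 3 `Cc1nn(-c2ccccc2)c2c1C(c1ccccc1)=NCC(=O)N2` gives > 40 mg/kg, also a limit of the assay.

Compound 2 differs from compound 1 by chloro in place of hydrogen on an aromatic carbon, and this change made an at least 4.0-fold higher number from compound 1 to compound 2 (0.60 log units; beyond the scatter). The two cores differ by phenyl in place of methyl on an aromatic nitrogen, a change that made an at least 4.0-fold higher number from compound 1 to compound 3 (0.60 log units; beyond the scatter). Compound 4 `Cc1nn(-c2ccccc2)c2c1C(c1ccccc1Cl)=NCC(=O)N2` has not been measured; it differs from compound 3 by chloro in place of hydrogen on an aromatic carbon. In compound 2 the chloro sits meta to a large group, while in compound 4 it sits ortho to a large group, so this is the same kind of change, not the same. The expected step is a step that the limit leaves unreadable from compound 3 to compound 4, resting on compound 3 sitting at the limit of > 40 mg/kg in this assay, at which 2 of the 3 values shown sit, and on the earlier chloro step an at least 4.0-fold higher number from compound 1 to compound 2 (0.60 log units; beyond the scatter). Compound 4 is estimated at 80 mg/kg, expected to fall between 30 mg/kg and 300 mg/kg.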

Compound 4, minimum effective dose: 20 mg/kg
Beside the measured number, compound 4's estimate is 4.0-fold (0.60 log units) above it; measured number below the stated range.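

In this assay, the chloro change gave an at least 2.0-fold lower number from compound 3 to compound 4 (0.30 log units; that floor lies within the scatter), so it does not carry over unchanged from one core to the other: the same change on two cores in this assay, an at least 4.0-fold higher number (0.60 log units; beyond the scatter) from compound 1 to compound 2 and an at least 2.0-fold lower number (0.30 log units; that floor lies within the scatter) from compound 3 to compound 4, at least 8.0-fold (0.90 log units) apart, beyond the scatter of two such steps
Compound 3 gives > 40 mg/kg, which is a limit of the assay and not a number.
The comparison does not show whether the core or the place of the chloro sets the two steps apart: in compound 4 the chloro sits ortho to a large group, and in compound 2 it does not.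

Still open, going by these compounds, is what a chloro ortho to a large group would do on the core of compound 1. Also open, on these data alone, is what a fluoro or a methoxy in that place would do on either core.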